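Removal of the side chain: compound 3 to compound 4

This account rests on a few compounds, and the source may have more. Where it says the series, first, only, none or still open, it means among the compounds named here.

Compound 3 `NC(=O)C[C@H](NC(=O)CN(c1nc(Cl)nc2[nH]cnc12)C1CC1)C(=O)O` carries a carbamoylmethyl group on the saturated chain carbon bound to an amide-type nitrogen and a carbonyl carbon. Among the compounds with values here, in a functional assay on the whole organism (Tail, strain ICR) with Mus musculus as the target, in the tail flick test, with a stated time of 120 min, at a dose of 25 umol/kg by the oral route (a higher number here means a stronger effect of the compound at the dose given, a lower number a weaker effect), compound 3 gives 17%, second highest of the three numbers measured so far. Compound 1 `O=C(O)[C@@H]1CCCN1C(=O)CN(c1nc(Cl)nc2[nH]cnc12)C1CC1` gives 23.6%, within the scatter of compound 3. Compound 2 `CSCC[C@H](NC(=O)CN(c1nc(Cl)nc2[nH]cnc12)C1CC1)C(=O)O` gives 5.67%, and the step of a number 11.3 percentage points higher from compound 2 to compound 3 (beyond the scatter) is the only one in the set that lies beyond the scatter. Compound 4 `O=C(O)CNC(=O)CN(c1nc(Cl)nc2[nH]cnc12)C1CC1` differs from compound 3 in a single place: hydrogen in place of carbamoylmethyl on a saturated chain carbon bound to an amide-type nitrogen and a carbonyl carbon. Within the data shown here, no measured step removes a side chain at this place; the one step known exchanges one group for another there, while compound 1 shows that a group of quite different build reaches a comparable number. Nothing measured therefore points clearly up or down for compound 4. The step expected is a number 2 percentage points lower from compound 3 to compound 4 (within the scatter), which is to say none beyond the scatter. For compound 4 the estimate is 15%, with a range from 4% to 28%.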

Compound 4, a percentage reported as activity, at one dose (the size of the read-out at that dose, not a potency): 19.8%
Compound 4: the middle estimate sits 4.8 percentage points below what was measured, and the stated range covers the measured number.
By their numbers in this assay, from the lowest: compound 2; then compounds 3, 4 and 1 (each within the scatter of the next).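

Cutting the side chain back to hydrogen changes nothing that can be read in this assay (a number 2.8 percentage points higher from compound 3 to compound 4 (within the scatter)), so the carbamoylmethyl group is not required at this saturated chain carbon for the effect at this dose. The same hydrogen sets the 2-(methylsulfanyl)ethyl compound apart (a number 14.1 percentage points higher from compound 2 to compound 4 (beyond the scatter)), whereas exchanging 2-carboxypyrrolidin-1-yl for (carboxymethyl)amino on the carbonyl carbon gives no readable change (a number 3.8 percentage points lower from compound 1 to compound 4 (within the scatter)), which leaves compound 2 as the only one of the four beyond the scatter of compound 4. Nothing measured on these compounds accounts for these steps.

Still open, from the compounds shown here alone, is whether a simple alkyl chain such as butyl, a carboxylic acid or a primary amine at this carbon would track hydrogen or 2-(methylsulfanyl)ethyl. With a single dose and time point, potency also remains undefined.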